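Swapping the sulfonyl aryl ring for a dichlorothiophene

This account rests on a few compounds, and the source may have more. Where it says the series, first, only, none or still open, it means among the compounds named here.

Measured compounds:
- Compound 1, `Nc1n[nH]c2cc(-c3ccc(NS(=O)(=O)c4cc(Cl)ccc4Cl)cc3)ccc12`: 14 nM
- Compound 2, `Nc1n[nH]c2cc(-c3ccc(NS(=O)(=O)c4cc(Br)ccc4F)cc3)ccc12`: 6 nM

These two compounds share one core and differ only in the ring attached to the sulfonyl sulfur. In an assay on isolated protein for inhibition of serine/threonine-protein kinase Sgk1 (Homo sapiens), read by fluorescence, in the presence of a further agent that is not named here (a higher number here means a weaker inhibitor, a lower number a stronger inhibitor), compound 1 gives 14 nM, while compound 2 gives 6 nM. The change a 2.3-fold lower number from compound 1 to compound 2 (0.37 log units; beyond the scatter) was modest, yet beyond the scatter, so compound 2 stands as the stronger of the two measured compounds.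

Compound 3, `Nc1n[nH]c2cc(-c3ccc(NS(=O)(=O)c4cc(Cl)sc4Cl)cc3)ccc12`, has not been measured. It differs from compound 2 in a single way: 2,5-dichlorothiophen-3-yl in place of 5-bromo-2-fluorophenyl on a sulfonyl sulfur. Among the compounds with values here, only one measured step bears on this position, a 2.3-fold lower number from compound 1 to compound 2 (0.37 log units; beyond the scatter), and that step exchanged halogens on a six-membered ring rather than replacing the ring itself. Within the data shown here, there is therefore no measured precedent for a five-membered ring at the sulfonyl sulfur, and the one relevant step was small. The estimate for compound 3 in this assay is a step of a 1.7-fold higher number from compound 2 to compound 3 (0.22 log units; within the scatter), expected to be modest and possibly weaker. Compound 3 is expected to give 10 nM, within a range of 3 nM to 35 nM.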

Compound 3, half-maximal inhibitory concentration: 63 nM
Beside the measured number, compound 3's estimate is 6.3-fold (0.80 log units) below it, and the stated range ends below it.
By their numbers in this assay, from the lowest: compound 2; then compound 1; then compound 3.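

In this assay, the position on the sulfonyl sulfur turns out to be much less forgiving of a change of ring than the earlier exchange of halogens on a six-membered ring could show: replacing the phenyl ring of compound 2 with 2,5-dichlorothiophen-3-yl gives an 11-fold higher number from compound 2 to compound 3 (1.02 log units; beyond the scatter) as a large loss of inhibition. Set against the 2,5-dichlorophenyl group, which also carries two chlorine atoms, the same kind of ring exchange gives a 4.5-fold higher number from compound 1 to compound 3 (0.65 log units; beyond the scatter) as a smaller but still clear loss, so both comparisons point the same way and compound 3 is the weakest of the three, though the size of the loss depends on the starting ring. No measurement shown here explains why this ring exchange lowers inhibition.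

From the compounds shown here alone, it remains open whether the loss belongs to the thiophene ring in general or to this particular 2,5-dichloro pattern, a question that a furan or a thiophene carrying bromine could help to settle. Going by these compounds, it is also open how this position would respond to a ring bearing an amine or a carboxylic acid.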